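The source may hold more compounds than are shown below. What is called first, only, known or untested is meant among the compounds shown, and "the series" means these compounds.

Compound 1 `Cc1cc(O)c(C2=NN(c3ccc(S(N)(=O)=O)cc3)C(c3ccccc3Cl)C2)cc1Cl` and compound 2 `COc1ccc(C2CC(c3cc(Cl)c(C)cc3O)=NN2c2ccc(S(N)(=O)=O)cc2)cc1OC` share a core and differ only in the aryl group on the saturated ring carbon. In a functional assay on OVCAR-3 cells (Homo sapiens) for antiproliferative activity, with a stated time of 48 h (a lower number here means a stronger inhibitor of growth, a higher number a weaker inhibitor of growth), compound 1 gives 3580 nM, and compound 2 gives 9800 nM, the higher of the two numbers; the step of a 2.7-fold higher number from compound 1 to compound 2 (0.44 log units; beyond the scatter) lies beyond the scatter. Compound 3 `COc1ccc(C2CC(c3cc(Cl)c(C)cc3O)=NN2c2ccc(S(N)(=O)=O)cc2)c(OC)c1OC` carries the change (methoxy in place of hydrogen on an aromatic carbon). Within the data shown here, no measured step touches this place, and the one step known concerns a swap of the whole aryl group, so it bears only loosely. Compound 3 is therefore expected to show a 1.2-fold higher number from compound 2 to compound 3 (0.09 log units; within the scatter), with an estimate of 12000 nM and a range from 5000 nM to 30000 nM.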

Compound 3, concentration for total growth inhibition: 4770 nM
For compound 3 the middle estimate is 2.5-fold (0.40 log units) above the measured one, and the stated range ends above it.
By their numbers in this assay, from the lowest: compounds 1 and 3 (each within the scatter of the next); then compound 2.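

In this assay, among these compounds, methoxy in place of hydrogen on an aromatic carbon, ortho to a large group, gives a 2.1-fold lower number from compound 2 to compound 3 (0.31 log units; beyond the scatter) and so shows that this carbon, which no earlier step touched, responds to substitution. The 2,3,4-trimethoxyphenyl group also stands within the scatter of the 2-chlorophenyl group, at a 1.3-fold higher number from compound 1 to compound 3 (0.12 log units; within the scatter) in the same assay, which the 3,4-dimethoxyphenyl group did not. On these data alone, whether a hydroxyl or an amine on this carbon would do the same remains open, as does whether methoxy here needs the other two methoxy groups. No evidence is at hand that explains this step.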